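Cyclobutyl for 1-cyclopropylethyl on the aromatic nitrogen

The compounds below may be only part of what the source reports. "The series", "measured", "known", "first", "only" and "open" are said of these compounds alone.

Compound 2, with the structure `CC(C1CC1)n1cnc2c(N(C=O)C3CC3)ncnc21`, is the anchor of this comparison. Within the data shown here, in a functional assay on the whole organism for antagonist activity, with Rattus norvegicus as the target (on this read-out higher numbers stand for an effect only at larger amounts of compound and lower numbers for an effect already at smaller amounts), compound 2 gives 2.5 mg/kg, the only number it has there, while a further entry for compound 2 in this assay carries no single number. Compound 1, with the structure `CC(C1CC1)n1cnc2c(NC3CC3)ncnc21`, shares the core and in this assay compound 1 gives 2 mg/kg; 4.5 mg/kg; 12.5 mg/kg (3 entries); the spread of those entries, (the several entries of compound 1 in this assay, 2 mg/kg; 4.5 mg/kg; 12.5 mg/kg (3 entries)), shows how far repeated measurements of this kind can move. Compound 3, with the structure `O=CN(c1ncnc2c1ncn2C1CCC1)C1CC1`, has not yet been measured in this assay. It differs from compound 2 in one place: cyclobutyl in place of 1-cyclopropylethyl on an aromatic nitrogen. No measured step of this kind is available among these compounds, so the change from compound 2 to compound 3 in this assay is expected to be a 1.6-fold higher number from compound 2 to compound 3 (0.20 log units; within the scatter), small and not clearly beyond the scatter in either direction. On that basis compound 3 is estimated to give 4 mg/kg in this assay, within a range from 1.5 mg/kg to 12 mg/kg.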

Compound 3, dose for half-maximal effect: 20 mg/kg
The estimate for compound 3 lay 5.0-fold (0.70 log units) below the measured number; measured number above the stated range.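

In this assay, among these compounds, cyclobutyl in place of 1-cyclopropylethyl on the aromatic nitrogen gives an 8.0-fold higher number from compound 2 to compound 3 (0.90 log units; beyond the scatter), so this position, which stays the same in the earlier compounds, does respond to the group it carries. The change is small when counted, with 4 heavy atoms for 5 and a four-membered ring for a three-membered one, and neither group has a hydrogen-bond donor or acceptor, yet the step still lies beyond the scatter. As a single entry for compound 3, it should be read against how far repeated entries can run on this read-out: the several entries of compound 1 in this assay, 2 mg/kg; 4.5 mg/kg; 12.5 mg/kg (3 entries).

The compounds shown leave open whether the higher number follows from the cyclobutyl ring itself or from the loss of 1-cyclopropylethyl, a question that a cyclopentyl or an isopropyl group on the same nitrogen would help to settle. They also do not show whether the step would be of the same size on the core of compound 1, which lacks the formyl group.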